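Swapping trifluoromethyl for methoxy on a weak growth inhibitor

A few compounds are considered here, and "the series" means these few. Any claim that something is new, unique, unknown or untested is made for them only; others in the source may bear on it.

Among the compounds with values here, in a functional assay on A2780 cells (Homo sapiens) for inhibition, read by sulforhodamine B assay (a higher number here means a weaker inhibitor of growth, a lower number a stronger inhibitor of growth), compound 3 `FC(F)(F)c1ccc(-c2ccc(-c3ccc(-c4nc5ccccc5[nH]4)cc3)cc2)cc1` gives 100000 nM, the highest of the three numbers so far, which makes it the weakest inhibitor measured. Compound 2 `Fc1ccc(-c2ccc(-c3ccc(-c4nc5ccccc5[nH]4)cc3)cc2)cc1` gives 48200 nM, and compound 1 `COc1ccc(-c2ccc(-c3ccc(-c4nc5cc(C)ccc5[nH]4)cc3)cc2)cc1OC` gives 2130 nM. Compound 4 `COc1ccc(-c2ccc(-c3ccc(-c4nc5ccccc5[nH]4)cc3)cc2)cc1` has not yet been measured. It carries methoxy in place of trifluoromethyl on an aromatic carbon.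

Within the data shown here, only one measured step changes this same place, a 2.1-fold higher number from compound 2 to compound 3 (0.32 log units; beyond the scatter). That step is modest, though beyond the scatter, and it does not involve methoxy. Among the measured compounds shown here, the only measured compound with methoxy groups is compound 1, which also differs from compound 3 elsewhere, so it offers a hint and not a clean comparison. For compound 4 a lower number is still expected, going by compound 1 at 2130 nM. The expected change is a moderate gain in strength, estimated as an 8.3-fold lower number from compound 3 to compound 4 (0.92 log units; beyond the scatter). For compound 4 the estimated value is 12000 nM, within a range from 2500 nM to 50000 nM.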

Compound 4, concentration for 50% growth inhibition: 100000 nM
For compound 4 the middle estimate is 8.3-fold (0.92 log units) below the measured one; measured number above the stated range.
By their numbers in this assay, from the lowest: compound 1; then compound 2; then compounds 3 and 4 (each within the scatter of the next).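

In this assay, replacing trifluoromethyl with methoxy at this position gives no change at the digits printed from compound 3 to compound 4 (within the scatter), so the hydrogen-bond acceptor counted for methoxy and absent from trifluoromethyl comes with no shift in the number. Methoxy in place of fluoro gives a 2.1-fold higher number from compound 2 to compound 4 (0.32 log units; beyond the scatter), a modest step that matches the one already seen with trifluoromethyl, so among these three groups only fluoro stands apart from the other two. Nothing measured here explains this pattern.

As far as these compounds go, compound 1, at 2130 nM, differs from the others in more than one place, so the separate contributions of its extra methoxy and its methyl remain open. From the compounds shown here alone, it is also open whether an amine or a carboxylic acid at this position would move the number at all.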